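Allyl nitrile-ether series: acetyl to propanoyl, compound 4

The source may report more compounds than this note shows. Statements on the series, on what has been measured and on what is new or still open speak of the compounds shown alone.

Measured in an assay on isolated protein for inhibition of leukotriene B4 receptor 1 (Homo sapiens), tested at 10 uM; on this read-out lower numbers stand for less inhibition and higher numbers for more inhibition at the one concentration tested (going by the name of the read-out):
compound 1, `CC(=O)c1ccc(OCCCCC#N)cc1O`: 0%
compound 2, `C=CCc1cc(C(C)=O)c(O)cc1OCCCCC#N`: 92%
compound 3, `C=CCc1cc(C(C)=O)c(O)cc1OCCCCCC#N`: 81%

Compound 2 holds the highest number of the three. Compound 3 is nearest, with a number 11 percentage points lower from compound 2 to compound 3 (beyond the scatter); compound 1 is furthest, with a number 92 percentage points higher from compound 1 to compound 2 (beyond the scatter), a large gain on adding the allyl group.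

Compound 4, `C=CCc1cc(C(=O)CC)c(O)cc1OCCCCC#N`, differs from compound 2 by methyl in place of hydrogen on a saturated chain carbon bound to a carbonyl carbon. Within the data shown here, no measured step touches this carbon; the two known steps concern the allyl group and the length of the nitrile chain. The nearest analogy is the chain-lengthening step from compound 2 to compound 3, which was modest, and adding one carbon here is a change of similar scale at a different place. The expectation for compound 4 in this assay is therefore a small loss or none beyond the scatter, with the step estimated as a number 8 percentage points lower from compound 2 to compound 4 (within the scatter).

Compound 4 is estimated at 84%, with a range from 62% to 97%.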

Compound 4, a percentage reported as inhibition, at one concentration (the size of the read-out at that concentration, not a potency): 77%
The estimate for compound 4 lay 7 percentage points above the measured number, within the range that was stated.
By their numbers in this assay, from the lowest: compound 1; then compounds 4 and 3 (each within the scatter of the next); then compound 2.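

In this assay, among these compounds, the change from acetyl to propanoyl gives a number 15 percentage points lower from compound 2 to compound 4 (beyond the scatter) and is the first step read at this saturated chain carbon bound to a carbonyl carbon, so this carbon is not indifferent to an added methyl. The step is modest, and compound 4 keeps 77% as a high number with the methyl in place. The data offer nothing that accounts for this loss.

From the compounds shown here alone, whether the number keeps falling with a butanoyl or isobutyryl group at this place remains open, as does the outcome with a carboxylic acid or an amide in place of the acetyl. Going by these compounds, it is also open whether the propanoyl group and the longer nitrile chain of compound 3 would together give a loss larger than either step alone.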